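The source may report more compounds than this note shows. Statements on the series, on what has been measured and on what is new or still open speak of the compounds shown alone.

Measured so far in a functional assay for agonist activity at G protein-coupled receptor 88 (Homo sapiens), read by HTRF and cAMP accumulation; a higher number here means that more compound is needed for the effect, a lower number that less compound is needed:
compound 1, `CC(C)C[C@H](N)CN(C(=O)[C@@H]1C[C@H]1c1ccccc1)c1ccc(-c2ccccc2)cc1`, gives 880 nM
compound 2, `CC(C)C[C@H](N)CN(C(=O)[C@@H]1C[C@H]1c1ccccc1)c1ccc(-c2cccs2)cc1`, gives 1500 nM
compound 3, `COc1ccccc1-c1ccc(N(C[C@@H](N)CC(C)C)C(=O)[C@@H]2C[C@H]2c2ccccc2)cc1`, gives 3200 nM

Compound 3 stands highest of the three numbers, with compound 2 nearest and compound 1 furthest. Compound 4, `CC(C)C[C@H](N)CN(C(=O)[C@@H]1C[C@H]1c1ccccc1)c1ccc(-c2ccc(Cl)cc2)cc1`, differs from compound 3 by 4-chlorophenyl in place of 2-methoxyphenyl on an aromatic carbon. Among the compounds with values here, two measured steps bear on this change: a 3.6-fold higher number from compound 1 to compound 3 (0.56 log units; beyond the scatter) and a 2.1-fold higher number from compound 2 to compound 3 (0.33 log units; beyond the scatter), both arriving at compound 3 with a higher number. Taking the methoxy away is therefore expected to bring the number back down; the chlorine has no measured precedent, though a 1.7-fold higher number from compound 1 to compound 2 (0.23 log units; within the scatter) shows that a change of the entering ring can stay within the scatter. Compound 4 is expected to give about 900 nM in this assay, between 300 nM and 2700 nM, amounting to a 3.6-fold lower number from compound 3 to compound 4 (0.55 log units; beyond the scatter).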

Compound 4, half-maximal effective concentration: 640 nM
Estimate against measurement, compound 4: 1.4-fold (0.15 log units) above; the measured number falls inside the stated range.
By their numbers in this assay, from the lowest: compounds 4, 1 and 2 (each within the scatter of the next, the first and the last beyond it); then compound 3.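

The step of a 5.0-fold lower number from compound 3 to compound 4 (0.70 log units; beyond the scatter) and the step of a 2.3-fold lower number from compound 2 to compound 4 (0.37 log units; beyond the scatter) in this assay show that this position, para to a large group, tolerates a 4-chlorophenyl group and that both steps lie beyond the scatter. The step of a 1.4-fold lower number from compound 1 to compound 4 (0.14 log units; within the scatter) shows that chloro in place of hydrogen on this ring leaves the number within the scatter of compound 1. No measurement shown here accounts for these differences. From the compounds shown here alone, whether the higher number of compound 3 follows from the methoxy group itself or from its place on the ring stays open, as does how a nitrile or an amine would read in place of the chlorine.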